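Amine variation on a shared core: three measured, one pending

This account rests on a few compounds, and the source may have more. Where it says the series, first, only, none or still open, it means among the compounds named here.

compound 1 `CCCN(CCC)Cc1ccc(Cl)c(-c2ccccc2OC)c1`: in an assay on isolated protein for binding affinity to 5-hydroxytryptamine receptor 1E (Homo sapiens) (a higher number here means a weaker inhibitor, a lower number a stronger inhibitor), compound 1 gives > 10000 nM, a limit of the assay rather than a number.
compound 2 `CCNCc1ccc(Cl)c(-c2ccccc2OC)c1`: compound 2 gives > 10000 nM, likewise a limit.
compound 3 `COc1ccccc1-c1cc(CN(C)C)ccc1Cl`: compound 3 gives 4100 nM.

Among the measured compounds shown here, compound 3 is the only member of the series with a numeric value in this assay; the other two sit at the limit (the limit of > 10000 nM in this assay, at which 2 of the 3 values shown sit). Compound 4 `CCCNCc1ccc(Cl)c(-c2ccccc2OC)c1` has not been measured. It differs from compound 3 by propylamino in place of dimethylamino on a saturated chain carbon bound to an aromatic carbon.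

For the measured compounds named here, two measured steps bear on this change, both running toward dimethylamino: an at least 2.4-fold lower number from compound 1 to compound 3 (0.38 log units; beyond the scatter) and an at least 2.4-fold lower number from compound 2 to compound 3 (0.38 log units; beyond the scatter). The third, a step that the two limits leave unreadable from compound 1 to compound 2, cannot be read since both ends are limits. The move to compound 4 runs in the opposite direction, away from dimethylamino toward a secondary amine with a propyl chain, so a higher number in this assay is expected, of at least modest size, with a real chance that only a limit is reported.

For compound 4 the expected result is 12000 nM, with a range of 4000 nM to 40000 nM, which corresponds to an expected step of a 2.9-fold higher number from compound 3 to compound 4 (0.47 log units; beyond the scatter).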

Compound 4, inhibition constant: > 10000 nM
Compound 4 was reported as a limit; the forecaster's own chance of this, stated with the estimate: 65%; the middle value lies beyond the limit too.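

In this assay, propylamino in place of dimethylamino on a saturated chain carbon bound to an aromatic carbon gives an at least 2.4-fold higher number from compound 3 to compound 4 (0.38 log units; beyond the scatter). A secondary amine with a propyl chain thus joins ethylamino and dipropylamino at the limit, leaving dimethylamino as the only amine in the series with a numeric reading: the limit of > 10000 nM in this assay, at which 3 of the 4 values shown sit. The steps from compound 1 and from compound 2 to compound 4 cannot be read, since both ends of each are limits, so compound 1, compound 2 and compound 4 cannot be ranked against one another.

As far as these compounds go, whether methylamino, a primary amine or a ring amine such as pyrrolidine would give a lower number than compound 3 at 4100 nM stays open. Also open, from the compounds shown here alone, is whether any amine on this shared core can reach a markedly lower number in this assay.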